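The compounds below may be only part of what the source reports. "The series", "measured", "known", "first", "only" and "open" are said of these compounds alone.

Within the data shown here, in a physicochemical assay for lipophilicity, read by NMR (a lower number here means a more polar compound, a higher number a more lipophilic compound), compound 3, `CCCC(F)CO`, gives 0.87, the highest of the three numbers measured so far. Compound 2, `CC[C@H](F)[C@H](C)O`, gives 0.68, a number within the scatter of compound 3, so the two cannot be ordered. Compound 1, `OCCCC(F)CF`, gives 0.11, a number beyond the scatter below compound 3. Compound 4, `CCC(F)CO`, has not yet been measured in this assay. It differs from compound 3 in one place: hydrogen in place of methyl on a saturated chain carbon, three bonds along the chain from a fluorine atom. Among the measured compounds shown here, no measured pair shows this same change, so the expectation rests on the change alone: a methyl leaves and a hydrogen enters, and in this assay the expected step is a number 0.50 log units lower from compound 3 to compound 4 (beyond the scatter), a fall beyond the scatter. Compound 4 is therefore estimated at 0.37, within 0 to 0.7.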

Compound 4, partition coefficient: 0.26
The estimate for compound 4 lay 0.11 log units above the measured number; the measured number falls inside the stated range.
By their numbers in this assay, from the lowest: compounds 1 and 4 (each within the scatter of the next); then compounds 2 and 3 (each within the scatter of the next).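

In this assay, hydrogen in place of methyl on a saturated chain carbon, three bonds along the chain from a fluorine atom, gives a number 0.61 log units lower from compound 3 to compound 4 (beyond the scatter) as the first step read between compounds differing in one place. This position therefore does not leave the number unchanged when the methyl goes. Nothing measured here accounts for the size of the step. Still open, on these data alone, is whether a longer chain at this place would move the number the other way, and whether an amine in place of the hydroxyl would leave this step intact.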